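Methyl for acetyl on the nitrogen of compound 3

This account rests on a few compounds, and the source may have more. Where it says the series, first, only, none or still open, it means among the compounds named here.

In a functional assay on A549 cells (Homo sapiens) for inhibition (on this read-out higher numbers stand for weaker inhibition and lower numbers for stronger inhibition), compound 1 `FC(F)(F)c1ccc(/C=C\c2ccc3ccccc3c2)cc1` returns > 5000 nM as a limit, not a number. Compound 2 `COc1cc(/C=C/c2cn(C(C)=O)c3ccccc23)cc(OC)c1OC` returns > 5000 nM as a limit as well. Within the data shown here, compound 3 `COc1cc(/C=C\c2cn(C(C)=O)c3ccccc23)cc(OC)c1OC` returns 2850 nM and is the only compound here with a number, while the limit of > 5000 nM in this assay, at which 2 of the 3 values shown sit, marks where the other two stand.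

One step has been measured: an at least 1.7-fold lower number from compound 2 to compound 3 (0.24 log units; that floor lies within the scatter) with the fact that compounds 2 and 3 differ only in the configuration as drawn as the whole structural difference. Its floor lies within the scatter, and it concerns the double bond, not the group on nitrogen.

Compound 4 `COc1cc(/C=C\c2cn(C)c3ccccc23)cc(OC)c1OC` keeps the Z double bond of compound 3 and differs as follows: methyl in place of acetyl on an aromatic nitrogen that is, methyl in place of acetyl on an aromatic nitrogen. Among the measured compounds shown here, no measured step covers this change, so the expectation stays broad and no shift beyond the scatter is assumed in this assay as the central case. The expected step is a 1.6-fold lower number from compound 3 to compound 4 (0.20 log units; within the scatter) and its direction remains uncertain. Compound 4 is estimated at 1800 nM with an expected range from 200 nM to 5000 nM.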

Compound 4, half-maximal inhibitory concentration: 3090 nM
Beside the measured number, compound 4's estimate is 1.7-fold (0.23 log units) below it; the range from low to high includes it.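

In this assay, methyl in place of acetyl on the aromatic nitrogen gives a 1.1-fold higher number from compound 3 to compound 4 (0.04 log units; within the scatter), with the Z double bond kept. The earlier compounds shown here held this position fixed as acetyl, and this pair shows that the carbonyl of acetyl can be removed here with no shift beyond the scatter, so acetyl is not required on this nitrogen for a value in this range. No measurement at hand speaks to what lies behind this step.

Acetyl and methyl are the only two groups compared at this nitrogen, so they set no trend, and an aminoethyl chain, a longer propyl chain or a carboxylic acid on a short chain could behave differently there. From the compounds shown here alone, it also remains open whether the E double bond paired with methyl on the nitrogen would give a number rather than a limit.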